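The source may hold more compounds than are shown below. What is called first, only, known or untested is meant among the compounds shown, and "the series" means these compounds.

Measured so far:
- compound 1, `O=C1COc2ccc(NC(=O)C3CCN(c4ccccc4Cl)CC3)cc2N1`, 220 nM
- compound 2, `O=C1COc2ccc(NC(=O)C3CCN(c4cc(F)c(F)c(F)c4)CC3)cc2N1`, 59 nM

For the measured compounds named here, in a functional assay for antagonist activity at transient receptor potential cation channel subfamily V member 1 (Homo sapiens), read by FLIPR and calcium flux (on this read-out higher numbers stand for weaker inhibition and lower numbers for stronger inhibition), compound 2 gives the lower of the two numbers recorded; the only neighbour is compound 1, and the gap between them, a 3.7-fold lower number from compound 1 to compound 2 (0.57 log units; beyond the scatter), is a modest one that lies beyond the scatter. Compound 3, `O=C1COc2ccc(NC(=O)C3CCN(c4cccc(Br)c4)CC3)cc2N1`, is not yet measured. It differs from compound 2 in one place: 3-bromophenyl in place of 3,4,5-trifluorophenyl on an amine nitrogen in a ring. Going by the values given here, the single step that bears on this change is the one from compound 1 to compound 2, which also exchanged the aryl group on the same ring nitrogen and moved the number by a 3.7-fold lower number from compound 1 to compound 2 (0.57 log units; beyond the scatter). That step shows this position tolerates a change of halogenated aryl group with a modest shift, but it gives no direct reading for 3-bromophenyl. For compound 3 the expectation in this assay is 100 nM, with a range of 35 nM to 300 nM. The expected step from compound 2, a 1.7-fold higher number from compound 2 to compound 3 (0.23 log units; within the scatter), is estimated to stay within or close to the scatter.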

Compound 3, half-maximal inhibitory concentration: 330 nM
Estimate against measurement, compound 3: 3.3-fold (0.52 log units) below; measured number outside the range, above it.
By their numbers in this assay, from the lowest: compound 2; then compounds 1 and 3 (each within the scatter of the next).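

In this assay the aryl group on the amine nitrogen does not behave as an interchangeable halogenated phenyl: 3-bromophenyl in place of 3,4,5-trifluorophenyl gives a 5.6-fold higher number from compound 2 to compound 3 (0.75 log units; beyond the scatter), so the better number of compound 2 does not carry over to compound 3. Set against 2-chlorophenyl, the same group gives a 1.5-fold higher number from compound 1 to compound 3 (0.18 log units; within the scatter), which stays within the scatter, so compound 1 and compound 3 cannot be separated and, of the three, only compound 2 stands apart. Nothing measured on these compounds accounts for the difference.

The step from compound 2 to compound 3 changes both the halogen and the number of halogens, and the compounds shown do not separate the two. Also open, going by these compounds, is how 3-fluorophenyl, or a phenyl group carrying methoxy or trifluoromethyl, would read at this nitrogen.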